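This account rests on a few compounds, and the source may have more. Where it says the series, first, only, none or still open, it means among the compounds named here.

Measured compounds: compound 1, `CCN(CC)CCNC(=O)C1CC(C(CC)(CC)c2ccc(C#CC(C)(C)O)c(C)c2)=CN1CC`, with 56.3%; compound 2, `CCN(CC)CCNC(=O)C1CC(C(CC)(CC)c2ccc(C#CC(O)C3CCCCC3)c(C)c2)=CN1CC`, with 44.2%; compound 3, `CCN(CC)CCNC(=O)C1CC=C(C(CC)(CC)c2ccc(C#CC(C)(C)O)c(C)c2)N1CC`, with 60.2%.

In an assay on isolated protein for binding affinity to vitamin D3 receptor (Homo sapiens), read by fluorescence polarization, tested at 1 uM (on this read-out lower numbers stand for less inhibition and higher numbers for more inhibition at the one concentration tested (going by the name of the read-out)), compound 3 gives the highest of the three numbers, though compound 1 lies within the scatter of it, and only compound 2 lies beyond the scatter below it. Compound 4, `CCN(CC)CCNC(=O)C1CC=C(C(CC)(CC)c2ccc(C#CC(C)(O)CC)c(C)c2)N1CC`, differs from compound 3 by methyl in place of hydrogen on a saturated chain carbon, two bonds along the chain from an oxygen on a saturated carbon and a triple-bonded carbon. For the measured compounds named here, the one measured step that touches the same part of the molecule is a number 12.1 percentage points lower from compound 1 to compound 2 (beyond the scatter), a larger change at the carbon bearing the oxygen than the one made here. The change in compound 4 is smaller, so a step of at most modest size downward, and possibly none beyond the scatter, is expected for a number 5.2 percentage points lower from compound 3 to compound 4 (within the scatter). Compound 4 is therefore estimated at 55%, in a range from 42% to 66%.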

Compound 4, a percentage reported as inhibition, at one concentration (the size of the read-out at that concentration, not a potency): 63.4%
Compound 4: the middle estimate sits 8.4 percentage points below what was measured; the range from low to high includes it.
By their numbers in this assay, from the lowest: compound 2; then compounds 1, 3 and 4 (each within the scatter of the next).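

In this assay, the change to 1-hydroxy-1-methylpropyl gives a number 3.2 percentage points higher from compound 3 to compound 4 (within the scatter), so this chain carbon takes methyl in place of hydrogen with no change that can be told from the scatter. The earlier change at the carbon bearing the oxygen, a number 12.1 percentage points lower from compound 1 to compound 2 (beyond the scatter), had shown only a much larger replacement. Nothing available explains this result. Still open, from the compounds shown here alone, is whether a longer chain or an amine at this position would keep the number, and whether the same methyl change behaves alike on the core of compound 1.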